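Heteroaryl swap at the amide-nitrogen carbon: compound 3

The source may report more compounds than this note shows. Statements on the series, on what has been measured and on what is new or still open speak of the compounds shown alone.

Measured compounds: compound 1 `Cc1noc(C)c1-c1ccc2c(c1)C(c1ccccc1)N(Cc1ncc(-c3ccccc3)o1)C(=O)N2C` with 50.6% in a functional assay on HepG2 cells (Homo sapiens) for inhibition, read by MTT assay, with a stated time of 48 h, tested at 2 uM; on this read-out lower numbers stand for less inhibition and higher numbers for more inhibition at the one concentration tested (going by the name of the read-out); compound 2 `Cc1nc(-c2ccccc2)sc1CN1C(=O)N(C)c2ccc(-c3c(C)noc3C)cc2C1c1ccccc1` with 29.2% in this assay.

Compound 2 stands at the lower of the two numbers shown, and the one measured step is a number 21.4 percentage points lower from compound 1 to compound 2 (beyond the scatter). Within the data shown here, that single step, which exchanged one five-membered heteroaryl for another on the saturated chain carbon bound to the amide-type nitrogen in the ring, is the only measured change that bears on compound 3 `Cc1noc(C)c1-c1ccc2c(c1)C(c1ccccc1)N(Cc1nnc(-c3ccccc3)s1)C(=O)N2C`.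

The change from compound 2 to compound 3 is 5-phenyl-1,3,4-thiadiazol-2-yl in place of 4-methyl-2-phenyl-1,3-thiazol-5-yl on a saturated chain carbon bound to an amide-type nitrogen in a ring. Among the measured compounds shown here, it again replaces the heteroaryl group at the same place, so the one comparable step suggests that such a swap can shift the read-out in this assay by a modest amount beyond the scatter, but it gives no guide to direction, since neither group of compound 3 has been measured on this scaffold. Compound 3 is therefore expected to land somewhere between the two measured values, with an expected step of a number 8.8 percentage points higher from compound 2 to compound 3 (within the scatter). The estimate for compound 3 is 38%, with a range from 18% to 60%.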

Compound 3, a percentage reported as inhibition, at one concentration (the size of the read-out at that concentration, not a potency): 35.2%
For compound 3 the middle estimate is 2.8 percentage points above the measured one; the measured number falls inside the stated range.
By their numbers in this assay, from the lowest: compounds 2 and 3 (each within the scatter of the next); then compound 1.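

In this assay the second heteroaryl swap at this place, on a saturated chain carbon bound to an amide-type nitrogen in a ring, gives a number 6 percentage points higher from compound 2 to compound 3 (within the scatter) and so does not separate 5-phenyl-1,3,4-thiadiazol-2-yl from 4-methyl-2-phenyl-1,3-thiazol-5-yl. The direct comparison with the first group is a number 15.4 percentage points lower from compound 1 to compound 3 (beyond the scatter) and shows that a second, different replacement of 5-phenyl-1,3-oxazol-2-yl also gives a lower number, leaving compound 1 highest of these three compounds, with steps to both others beyond the scatter. Nothing available explains why the group in compound 1 stands apart from the other two.

The compounds shown leave open whether the phenyl ring on the heteroaryl matters at all, and whether a methoxy group, an amine or a carboxylic acid on that phenyl would change the number in this assay at this place. They also leave open whether a plain benzyl group or a longer chain between the ring nitrogen and the heteroaryl would keep the level of compound 1 or fall to that of compound 2 and compound 3.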